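The source may hold more compounds than are shown below. What is called first, only, known or untested is meant among the compounds shown, and "the series" means these compounds.

Values in a functional assay on A549 cells (Homo sapiens) for inhibition, read by MTT assay, with a stated time of 72 h; a lower number here means a stronger inhibitor, a higher number a weaker inhibitor:
compound 1 `Cc1ccc(S(=O)(=O)n2c(C3(O)C=CC(=O)C=C3)cc3ccccc32)cc1`: 500 nM
compound 2 `CCOC(=O)Nc1ccc(S(=O)(=O)n2c(C3(O)C=CC(=O)C=C3)cc3ccccc32)cc1`: 500 nM
compound 3 `COC(=O)CCc1ccc(S(=O)(=O)n2c(C3(O)C=CC(=O)C=C3)cc3ccccc32)cc1`: 500 nM

In this assay, compound 3 stands at 500 nM, level with the other two compounds. Next is compound 4 `O=C1C=CC(O)(c2cc3ccccc3n2S(=O)(=O)c2ccc(CCC(=O)O)cc2)C=C1`, which differs from compound 3 by hydrogen in place of methyl on an oxygen next to a carbonyl group. This turns methoxycarbonyl into carboxy.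

For the measured compounds named here, no measured step makes this exact change, so the evidence is indirect. The nearest comparisons are changes in the group carried at the same aromatic carbon: no change at the digits printed from compound 1 to compound 3 (within the scatter) and no change at the digits printed from compound 2 to compound 3 (within the scatter). The third comparison, no change at the digits printed from compound 1 to compound 2 (within the scatter), is no larger. These three steps show tolerance only among the methyl, (ethoxycarbonyl)amino and 2-(methoxycarbonyl)ethyl compounds, and none of these carries a carboxy group. The expected result is a 1.4-fold higher number from compound 3 to compound 4 (0.15 log units; within the scatter), so no step beyond the scatter is predicted, although the range is left wider on the weaker side given the lack of any measured carboxy compound. For compound 4 the estimated value is 700 nM, with an expected range of 300 nM to 2500 nM.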

Compound 4, half-maximal inhibitory concentration: 500 nM
For compound 4 the middle estimate is 1.4-fold (0.15 log units) above the measured one, and the stated range covers the measured number.
By their numbers in this assay, from the lowest: compounds 1, 2, 3 and 4 (each within the scatter of the next).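

In this assay, for the compounds shown here, hydrogen in place of methyl on the oxygen next to the carbonyl group gives no change at the digits printed from compound 3 to compound 4 (within the scatter) and adds the only carboxy compound in the set, so this ester-to-acid change is now measured directly. The other two comparisons read the same way, with no change at the digits printed from compound 2 to compound 4 (within the scatter) and no change at the digits printed from compound 1 to compound 4 (within the scatter), which extends the tolerance seen among the methyl, (ethoxycarbonyl)amino and 2-(methoxycarbonyl)ethyl compounds to the 2-carboxyethyl group in these four compounds. No supporting measurement bears on why this change leaves the reading flat.

With all four compounds level, the set does not show which group on this aromatic carbon, if any, would move the value beyond the scatter. On these data alone, whether an amine or a primary amide in place of the 2-carboxyethyl group would read the same remains open.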